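Methylsulfonyl for thiazolylsulfonyl on the shared sulfonamide

The compounds below may be only part of what the source reports. "The series", "measured", "known", "first", "only" and "open" are said of these compounds alone.

Compound 1 `CC(C)(C)c1ccc(CN(Cc2cccc(CCC(=O)O)c2)S(=O)(=O)c2nccs2)cc1` stands at the lowest number of the two that are known here. In a functional assay on HEK293 cells for agonist activity at prostaglandin E2 receptor EP2 subtype (Rattus norvegicus), read by cAMP accumulation (a lower number here means that less compound is needed, a higher number that more compound is needed for the effect), compound 1 gives 1.1 nM. Its nearest neighbour on the numbers is compound 2 `CCCCc1ccc(CN(Cc2cccc(CCC(=O)O)c2)S(C)(=O)=O)cc1`, which in this assay gives 34.4 nM, a gap well beyond the scatter; compound 2 does not differ from compound 1 in a single place, so the gap cannot be assigned to one change. Compound 3 `CCCCc1ccc(CN(Cc2ccccc2OCC(=O)O)S(C)(=O)=O)cc1` has no result in this assay; for compound 3 the entry reads "not determined" (no result reported).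

Compound 4 `CC(C)(C)c1ccc(CN(Cc2cccc(CCC(=O)O)c2)S(C)(=O)=O)cc1` is the next entry. It differs from compound 1 in one place: methyl in place of 1,3-thiazol-2-yl on a sulfonyl sulfur. Among the measured compounds shown here, no pair of measured compounds shows this change alone. Compound 2 also carries a methylsulfonyl group and sits at a much higher number than compound 1, but it differs in a second place as well, so only part of that gap, if any, can belong to the sulfonyl substituent.

The expectation for compound 4 is a step in this assay of a 7.3-fold higher number from compound 1 to compound 4 (0.86 log units; beyond the scatter), a rise in the number that is smaller than the gap from compound 1 to compound 2. The estimate for compound 4 in this assay is 8 nM, with a range from 2 nM to 30 nM.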

Compound 4, half-maximal effective concentration: 48 nM
Compound 4: the middle estimate sits 6.0-fold (0.78 log units) below what was measured; measured number outside the range, above it.
By their numbers in this assay, from the lowest: compound 1; then compounds 2 and 4 (each within the scatter of the next).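

In this assay the sulfonyl substituent now has a reading of its own: methyl in place of 1,3-thiazol-2-yl on a sulfonyl sulfur is a large step (a 44-fold higher number from compound 1 to compound 4 (1.64 log units; beyond the scatter)), so the low number of compound 1 does not survive this change. The other place behaves differently, at least with methylsulfonyl on the sulfonamide nitrogen: tert-butyl in place of butyl on an aromatic carbon stays within the scatter (a 1.4-fold higher number from compound 2 to compound 4 (0.14 log units; within the scatter)), and these two groups cannot be told apart in this pair. No measurement shown here explains either step.

As far as these compounds go, only two substituents on the sulfonyl sulfur can be compared, so it remains open whether the low number is tied to 1,3-thiazol-2-yl or would also be reached with phenyl, pyridyl or a longer alkyl chain at that place. From the compounds shown here alone, it is also open whether tert-butyl and butyl would remain indistinguishable with 1,3-thiazol-2-yl on the sulfonyl sulfur, since that pairing has only the tert-butyl member here.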